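Sulfonamide series: swapping the aniline substituent for carboxymethyl

A few compounds are considered here, and "the series" means these few. Any claim that something is new, unique, unknown or untested is made for them only; others in the source may bear on it.

Measured compounds:
compound 1 `Cc1noc(NS(=O)(=O)c2ccc(N/C(S)=N/c3ccccc3)cc2)c1C` — 4100 nM
compound 2 `Cc1noc(NS(=O)(=O)c2ccc(F)cc2)c1C` — 1000 nM
compound 3 `Cc1noc(NS(=O)(=O)c2ccc(NC(=O)Nc3ccccc3)cc2)c1C` — 38000 nM

In an assay on VSM-A10 cells for antagonist activity at Endothelin-1 receptor (Rattus norvegicus) (on this read-out lower numbers stand for stronger inhibition and higher numbers for weaker inhibition), compound 3 stands highest of the three numbers. Its nearest neighbour is compound 1, which sits at 4100 nM; compound 2, the smallest of the set, gives 1000 nM in this assay, the lowest number shown.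

The new compound 4 `Cc1noc(NS(=O)(=O)c2ccc(NCC(=O)O)cc2)c1C` is derived from compound 3 by carboxymethyl in place of phenylcarbamoyl on a nitrogen on an aromatic ring.

Within the data shown here, only one measured step concerns a change on this same nitrogen: a 9.3-fold higher number from compound 1 to compound 3 (0.97 log units; beyond the scatter). It shows that the group on this nitrogen moves the number a good deal, and that the larger and more elaborate group of compound 3 sits at the unfavourable end. Compound 2, with no group on a nitrogen at this position at all, gives the lowest number of the three. Taken together these two observations point the same way: a change away from the phenylcarbamoyl of compound 3 towards a much smaller group is expected to bring the number down, beyond the scatter, though the size of the drop is uncertain because only compound 1 and compound 2 anchor it.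

The expected step is a 7.6-fold lower number from compound 3 to compound 4 (0.88 log units; beyond the scatter). Compound 4 is therefore estimated at 5000 nM, with a likely range of 1000 nM to 25000 nM.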

Compound 4, half-maximal inhibitory concentration: 12000 nM
For compound 4 the middle estimate is 2.4-fold (0.38 log units) below the measured one, and the stated range covers the measured number.
By their numbers in this assay, from the lowest: compound 2; then compound 1; then compound 4; then compound 3.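

In this assay, replacing phenylcarbamoyl with carboxymethyl on the nitrogen on an aromatic ring does bring the number down, with a 3.2-fold lower number from compound 3 to compound 4 (0.50 log units; beyond the scatter), but a 2.9-fold higher number from compound 1 to compound 4 (0.47 log units; beyond the scatter) shows that the much smaller carboxymethyl still sits on the unfavourable side of the sulfur-bearing, ring-carrying group of compound 1, so group size alone does not order the numbers at this nitrogen, and compound 1 is the one that goes against such a trend. The comparison with the fluoro compound is wider, at a 12-fold higher number from compound 2 to compound 4 (1.08 log units; beyond the scatter), so (carboxymethyl)amino in place of fluoro on the aromatic carbon leaves compound 4 well short of the lowest number in the set, and trimming the group on this nitrogen to carboxymethyl does not by itself recover the level of compound 2. Nothing shown here offers an explanation for these steps.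

Open, from the compounds shown here alone, is where the plain amino group or a small acetyl group on this nitrogen would fall relative to compound 2 and compound 4. Also open, going by these compounds, is whether the carboxylic acid itself matters, which the methyl ester of compound 4 or a longer chain such as carboxyethyl would test.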